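Amide-nitrogen substituents on a shared core: two measured, one pending

The source may report more compounds than this note shows. Statements on the series, on what has been measured and on what is new or still open speak of the compounds shown alone.

Measured so far:
compound 1, `COc1cccc(-c2nc(SC)nc3sc(C(=O)NCc4ccccc4)c(N)c23)c1`: 7.8%
compound 2, `COc1cccc(-c2nc(SC)nc3sc(C(=O)NCC#N)c(N)c23)c1`: 20.3%

In a functional assay on HEK293 cells for agonist activity at lutropin-choriogonadotropic hormone receptor (Homo sapiens), read by cAMP accumulation (on this read-out higher numbers stand for larger maximal responses and lower numbers for smaller maximal responses), compound 1 gives 7.8%; compound 2 gives 20.3%. For the measured compounds named here, compound 2 thus stands highest of the two numbers, and the single step between them, a number 12.5 percentage points higher from compound 1 to compound 2 (beyond the scatter), is the only one recorded. Compound 3, `COc1cccc(-c2nc(SC)nc3sc(C(=O)NN)c(N)c23)c1`, is not yet measured; it differs from compound 2 in one place: amino in place of cyanomethyl on an amide-type nitrogen. Going by the values given here, the one measured step concerns a different exchange on the same amide-type nitrogen, so it bears on this step only loosely: it shows that a replacement at this position can shift the maximal response by a modest amount. Among the compounds with values here, no direct precedent for an amino group here exists. The expected step from compound 2 to compound 3 is therefore a number 1.7 percentage points higher from compound 2 to compound 3 (within the scatter), a change not clearly beyond the scatter, with a wide range in either direction. Compound 3 is estimated at 22%, between 5% and 45%.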

Compound 3, largest response reached (reported as efficacy), in percent of the reference or control that the assay uses: 8.5%
Compound 3: the middle estimate sits 13.5 percentage points above what was measured; low and high end bracket the measured number.
By their numbers in this assay, from the lowest: compounds 1 and 3 (each within the scatter of the next); then compound 2.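

Replacing cyanomethyl with amino on this amide-type nitrogen gives back the gain seen earlier in this assay, as shown by a number 11.8 percentage points lower from compound 2 to compound 3 (beyond the scatter), so a higher maximal response does not follow from any change away from benzyl. Amino and benzyl, which differ in ring and heavy-atom count, cannot be told apart here, with a number 0.7 percentage points higher from compound 1 to compound 3 (within the scatter), and among these three groups only cyanomethyl stands apart. No measurement at hand accounts for this difference.

Still open, as far as these compounds go, is whether the nitrile group itself matters or the short chain carrying it does, a question that an ethyl group or a longer chain ending in a nitrile on the same nitrogen would address. A methylamino or dimethylamino group in place of amino would show whether the low number extends to substituted amines.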